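Hydroxy in Place of Methyl on an Aromatic Carbon

The compounds below may be only part of what the source reports. "The series", "measured", "known", "first", "only" and "open" are said of these compounds alone.

Among the compounds with values here, in a functional assay on A549 cells (Homo sapiens) for inhibition, read by CCK-8 assay, with a stated time of 72 h, tested at 1 uM (on this read-out higher numbers stand for more inhibition of growth at the one concentration tested and lower numbers for less inhibition of growth), compound 2 `Cc1ccc(NC(=O)C2(C(=O)Nc3ccc(Nc4ncc5cc(C(=O)N(C)C)n(C6CCCC6)c5n4)cc3)CC2)cc1` gives 40.2% and stands as the lower of the two numbers so far, while compound 1 `COc1ccc(NC(=O)C2(C(=O)Nc3ccc(Nc4ncc5cc(C(=O)N(C)C)n(C6CCCC6)c5n4)cc3)CC2)cc1` gives 74.4% in the same read-out. Compound 3 `CN(C)C(=O)c1cc2cnc(Nc3ccc(NC(=O)C4(C(=O)Nc5ccc(O)cc5)CC4)cc3)nc2n1C1CCCC1` has hydroxy in place of methyl on an aromatic carbon, para to a large group, a change counted as hydroxy in place of methyl on an aromatic carbon and not yet measured. Within the data shown here, only one measured step bears on it, the large a number 34.2 percentage points lower from compound 1 to compound 2 (beyond the scatter) with methyl in place of methoxy at that same place. Among the measured compounds shown here, a rise is therefore expected, an estimated a number 14.8 percentage points higher from compound 2 to compound 3 (beyond the scatter) in size, though no hydroxy example has been measured. The estimate for compound 3 is 55% with an expected range from 30% to 80% in this read-out.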

Compound 3, percent growth inhibition at one concentration: 93.6%
Compound 3: middle estimate off by 38.6 percentage points, on the low side; measured number outside the range, above it.
By their numbers in this assay, from the lowest: compound 2; then compound 1; then compound 3.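

At this position, hydroxy in place of methyl gives a number 53.4 percentage points higher from compound 2 to compound 3 (beyond the scatter) in this assay, so the ring carbon para to a large group tolerates a far larger rise than the methoxy example alone had shown. Loss of the methyl from the oxygen adds to this, with a number 19.2 percentage points higher from compound 1 to compound 3 (beyond the scatter), so that methyl is not needed for inhibition of growth here. Nothing in the data at hand accounts for this order. As far as these compounds go, whether an amine or a carboxylic acid on this carbon would match hydroxy remains open. So does whether the order of the three compounds holds at other concentrations.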